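Swapping methoxy for chloro on a benzylamine sulfonamide

This account rests on a few compounds, and the source may have more. Where it says the series, first, only, none or still open, it means among the compounds named here.

Three sulfonamides built on one shared core have been measured in a functional assay on MIA PaCa-2 cells (Homo sapiens) for inhibition, read by MTT assay, with a stated time of 72 h; on this read-out lower numbers stand for stronger inhibition of growth and higher numbers for weaker inhibition of growth. Compound 1 `O=S(=O)(NCCCNCc1ccccc1Cl)c1cc(C(F)(F)F)cc(C(F)(F)F)c1` gives 11000 nM. Compound 2 `O=S(=O)(NCCCNCC1COc2ccccc2O1)c1cc(C(F)(F)F)cc(C(F)(F)F)c1` gives 2600 nM, and compound 3 `COc1ccc(CNCCCNS(=O)(=O)c2cc(C(F)(F)F)cc(C(F)(F)F)c2)cc1` gives 2500 nM, the lowest of the three numbers, although compound 2 and compound 3 lie within the scatter of each other. The move to compound 4 `O=S(=O)(NCCCNCc1ccc(Cl)cc1)c1cc(C(F)(F)F)cc(C(F)(F)F)c1` is chloro in place of methoxy on an aromatic carbon. Among the compounds with values here, no measured pair makes exactly this change. The nearest guide is a 4.4-fold lower number from compound 1 to compound 3 (0.64 log units; beyond the scatter), a modest step in which the chlorine-bearing ring carries the higher number, but it concerns a 2-chlorophenyl, not a 4-chlorophenyl. On that loose basis compound 4 is expected to sit a little weaker than compound 3, with a 1.6-fold higher number from compound 3 to compound 4 (0.20 log units; within the scatter) as the expected step. The estimate for compound 4 is 4000 nM, with a range from 1500 nM to 11000 nM.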

Compound 4, concentration for 50% growth inhibition: 2800 nM
Beside the measured number, compound 4's estimate is 1.4-fold (0.15 log units) above it; the measured number falls inside the stated range.
By their numbers in this assay, from the lowest: compounds 3, 2 and 4 (each within the scatter of the next); then compound 1.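

In this assay, chloro and methoxy are interchangeable at this ring position, with a 1.1-fold higher number from compound 3 to compound 4 (0.05 log units; within the scatter). Replacing the 2,3-dihydro-1,4-benzodioxin-2-yl group with 4-chlorophenyl also changes little, with a 1.1-fold higher number from compound 2 to compound 4 (0.03 log units; within the scatter). A chlorine on the ring therefore does not by itself bring the high number seen with 2-chlorophenyl, as 4-chlorophenyl in its place gives a 3.9-fold lower number from compound 1 to compound 4 (0.59 log units; beyond the scatter). Nothing shown explains why the two chlorophenyl groups differ. Going by these compounds, it also remains open whether a hydroxyl, a nitrile or a trifluoromethyl at this ring position would keep the number at this level.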